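A few compounds are considered here, and "the series" means these few. Any claim that something is new, unique, unknown or untested is made for them only; others in the source may bear on it.

Of the compounds shown here, three have been measured in an ADME assay for solubility, in simulated intestinal fluid (on this read-out lower numbers stand for lower solubility and higher numbers for higher solubility), and all of them give high readings. In this assay, compound 1 (`O=C(Cc1ccc2c(c1)B(O)OC2)NS(=O)(=O)c1ccccc1`) gives 900 ug/mL. Compound 2 (`O=C(O)c1ccc2c(c1)B(O)OC2`) gives 950 ug/mL, and these two values lie within the scatter of each other. Compound 3 (`OB1OCc2ccc(Oc3nnn[nH]3)c(F)c21`) is reported as > 1000 ug/mL, which is a limit of the assay and not a number. Compound 1 therefore stands level with compound 2 on the numbers available, while the reading for compound 3 cannot be placed on the same scale.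

The next compound, compound 4 (`O=C(Cc1ccc2c(c1)B(O)OC2)NS(=O)(=O)C1CC1`), keeps the core of compound 1 and changes one group: cyclopropyl in place of phenyl on a sulfonyl sulfur, (cyclopropyl in place of phenyl on a sulfonyl sulfur). For the measured compounds named here, no measured pair in this small set isolates such a change, so no direct precedent exists for its size or direction. The expectation therefore starts from compound 1 at 900 ug/mL, with no step beyond the scatter anticipated in this assay. The expected 1.1-fold higher number from compound 1 to compound 4 (0.02 log units; within the scatter) is small and stays within the usual scatter. For compound 4 the estimated value is 950 ug/mL, with an expected range from 500 ug/mL to 1000 ug/mL.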

Compound 4, solubility: 700 ug/mL
The estimate for compound 4 lay 1.4-fold (0.13 log units) above the measured number; low and high end bracket the measured number.
By their numbers in this assay, from the lowest: compounds 4, 1 and 2 (each within the scatter of the next). At a limit, above all of these: compound 3.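

In this assay, for the compounds shown here, this is the first measured step at the sulfonyl sulfur of the core of compound 1, and a 1.3-fold lower number from compound 1 to compound 4 (0.11 log units; within the scatter) cannot be told apart from repeat measurement. Cyclopropyl, with 3 heavy atoms and a three-membered non-aromatic ring, therefore reads level with phenyl, with 6 heavy atoms and a six-membered aromatic ring, so an aromatic ring at this place is not required for readings of this height in this pair. Nothing measured here offers a cause for the step.

This single pair joins two carbon-only rings, so it leaves open how an amine, a carboxylic acid or a longer alkyl chain on the sulfonyl sulfur would read in this assay. As far as these compounds go, the reading of compound 3 is a limit and not a number, so how far it lies from the other compounds also stays open.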